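A few compounds are considered here, and "the series" means these few. Any claim that something is new, unique, unknown or untested is made for them only; others in the source may bear on it.

Two compounds share one core and differ only in the ring attached to the amine nitrogen of the six-membered ring bearing two nitrogens. Compound 1 `Nc1ccccc1NC(=O)c1ccc(CSC(=S)N2CCN(c3ccc(Cl)cc3)CC2)cc1` carries a chloro on that aromatic ring; in a functional assay on HeLa cells (Homo sapiens) for antiproliferative activity, read by CCK-8 assay, with a stated time of 72 h, tested at 8 uM (a higher number here means a stronger effect of the compound at the concentration tested, a lower number a weaker effect), compound 1 gives 44.8%. Compound 2 `Nc1ccccc1NC(=O)c1ccc(CSC(=S)N2CCN(c3ccccc3)CC2)cc1` has hydrogen in that place, and in this assay compound 2 gives 73.1%. The one measured step, a number 28.3 percentage points higher from compound 1 to compound 2 (beyond the scatter), places compound 2 highest of the two numbers shown, with compound 1 as its only neighbour.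

Compound 3 `Nc1ccccc1NC(=O)c1ccc(CSC(=S)N2CCN(c3cccnc3)CC2)cc1` takes the next step from compound 2: pyridin-3-yl in place of phenyl on an amine nitrogen in a ring. The measured step from compound 1 to compound 2 concerns the same ring but a different change, a substituent removed rather than a ring atom exchanged, so it bears on compound 3 only loosely. Nothing measured here shows what exchanging phenyl for pyridin-3-yl does. The step is therefore expected to be small or none beyond the scatter, a number 11.1 percentage points lower from compound 2 to compound 3 (beyond the scatter), with the range widened for the uncertainty. In this assay compound 3 is estimated at 62%, between 38% and 84%.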

Compound 3, a percentage reported as inhibition, at one concentration (the size of the read-out at that concentration, not a potency): 72.5%
Estimate against measurement, compound 3: 10.5 percentage points below; the range from low to high includes it.
By their numbers in this assay, from the lowest: compound 1; then compounds 3 and 2 (each within the scatter of the next).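

In this assay the result gives a number 0.6 percentage points lower from compound 2 to compound 3 (within the scatter) for pyridin-3-yl in place of phenyl, so at this place on the ring a ring nitrogen and its one hydrogen-bond acceptor can enter with no difference from the phenyl compound that this assay can resolve. The step of a number 27.7 percentage points higher from compound 1 to compound 3 (beyond the scatter) for pyridin-3-yl in place of 4-chlorophenyl is beyond the scatter, as is the earlier step of a number 28.3 percentage points higher from compound 1 to compound 2 (beyond the scatter), so among these three compounds only the chloro-bearing compound 1 stands apart, while the two rings without chloro read alike. No measurement shown here accounts for either finding.

From the compounds shown here alone, what remains open is whether the lower reading of compound 1 belongs to chloro in particular or would also appear with another group on the ring, such as fluoro, methyl or methoxy. Also open, going by these compounds, is how the ring nitrogen would fare in pyridin-2-yl or pyridin-4-yl, or whether a non-aromatic ring such as cyclohexyl could take the place of these aromatic rings, and each reading here comes from a single concentration and so gives no potency.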